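Swapping One Side Group on a Shared Core

The source may hold more compounds than are shown below. What is called first, only, known or untested is meant among the compounds shown, and "the series" means these compounds.

Measured in a functional assay on HepG2 cells (Homo sapiens) for inhibition, read by MTT assay, with a stated time of 48 h; a lower number here means a stronger inhibitor, a higher number a weaker inhibitor:
- compound 1 `CCOC(=O)C1=C(N/N=C(/C(=O)Br)c2ccc(Br)cc2)Nc2[nH]nc(C)c2C1c1ccc(N(C)C)cc1` gives 65000 nM
- compound 2 `CCOC(=O)C1=C(N/C=N/c2ncc(-c3ccccc3)s2)Nc2[nH]nc(C)c2C1c1ccc(N(C)C)cc1` gives 9790 nM

In this assay compound 2 stands at 9790 nM, the lower of the two numbers and so the stronger inhibitor, and the gap to compound 1 lies beyond the usual scatter. Compound 3 `CCOC(=O)C1=C(N/C=N/c2ccccn2)Nc2[nH]nc(C)c2C1c1ccc(N(C)C)cc1` carries pyridin-2-yl in place of 5-phenyl-1,3-thiazol-2-yl on a double-bonded nitrogen. For the measured compounds named here, no measured pair shows this swap, so the expectation rests on two values alone. Going by the values given here, the only other measured number lies above that of compound 2, so a moderate rise in this assay is expected, a 1.8-fold higher number from compound 2 to compound 3 (0.26 log units; within the scatter), which would mean a weaker inhibitor. For compound 3 the estimated value is 18000 nM, with an expected range of 6000 nM to 50000 nM.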

Compound 3, half-maximal inhibitory concentration: 26200 nM
Compound 3: middle estimate off by 1.5-fold (0.16 log units), on the low side; measured number inside the range.
By their numbers in this assay, from the lowest: compound 2; then compound 3; then compound 1.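

Placed on this double-bonded nitrogen, pyridin-2-yl in place of 5-phenyl-1,3-thiazol-2-yl gives a 2.7-fold higher number from compound 2 to compound 3 (0.43 log units; beyond the scatter) in this assay, so the number at this position depends on the group attached. The step of a 2.5-fold lower number from compound 1 to compound 3 (0.39 log units; beyond the scatter) shows that the group on the amine nitrogen also matters, though that swap changes much at once. Nothing available explains either step. Still open, from the compounds shown here alone, is whether the lower number of compound 2 goes with the thiazole ring or with its phenyl. A plain 1,3-thiazol-2-yl or a plain phenyl on this nitrogen would separate the two.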